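Swapping the aryl group on a paw edema compound

The compounds below may be only part of what the source reports. "The series", "measured", "known", "first", "only" and "open" are said of these compounds alone.

Compound 1 `Cc1cccc(/N=C2/NC(=O)/C(=C/c3ccccn3)S2)c1` was tested in a functional assay on the whole organism (strain Wistar) for inhibition, with Rattus norvegicus as the target, read by paw edema, with stated times of 30 min and 120 min, at a dose of 10 mg/kg by the oral route (a lower number here means less inhibition, a higher number more inhibition at the dose given (going by the name of the read-out)), where compound 1 gives 39.7%. Compound 2 `O=C1N/C(=N\Nc2ccccc2)S/C1=C\c1ccccn1` shares the same core, and in this assay compound 2 gives 39.7%, so the two stand level at the digits shown, within the usual scatter of such measurements. Compound 3 `O=C1N/C(=N/c2ccc(Br)cc2)S/C1=C\c1ccccn1` has not yet been measured. It differs from compound 1 in a single place: 4-bromophenyl in place of 3-methylphenyl on a double-bonded nitrogen. For the measured compounds named here, no measured pair shows what this kind of swap does here, so the size of the step has to be judged without a direct precedent; the one comparison in hand, between compound 1 and compound 2, shows no change beyond the scatter. For compound 3 the expected step of a number 0.3 percentage points higher from compound 1 to compound 3 (within the scatter) is none beyond the scatter. Compound 3 is estimated at 40%, with a range from 28% to 52%.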

Compound 3, a percentage reported as inhibition, in the whole organism at one dose (the size of the read-out at that dose, not a potency): 30.4%
Estimate against measurement, compound 3: 9.6 percentage points above; measured number inside the range.
By their numbers in this assay, from the lowest: compounds 3, 1 and 2 (each within the scatter of the next).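

For the compounds shown here, this pair gives the first direct reading of a swap at this place: in this assay, putting 4-bromophenyl in place of 3-methylphenyl on the double-bonded nitrogen gives a number 9.3 percentage points lower from compound 1 to compound 3 (within the scatter), a step that stays within the usual scatter. At this one dose, then, the measurement cannot separate a ring carrying a bromine from a ring carrying a methyl group. No measurement shown here bears on what lies behind these numbers.

On these data alone, both groups compared are six-membered carbon rings with no hydrogen-bond donors or acceptors, so it remains open whether a different kind of group would read the same. A carboxylic acid or an amine on that ring, or a longer chain in place of the ring, would show how much change this position allows.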